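The source may hold more compounds than are shown below. What is called first, only, known or untested is meant among the compounds shown, and "the series" means these compounds.

Compound 1 `CC(C)NS(=O)(=O)Cc1noc2ccccc12` was tested in a functional assay on the whole organism (strain STD-dd) with Mus musculus as the target, in the maximal electroshock model, with a stated time of 2 h (a lower number here means that less compound is needed, a higher number that more compound is needed for the effect), and compound 1 gives 56 mg/kg. Compound 2 `CN(C)S(=O)(=O)Cc1noc2ccccc12` carries dimethylamino in place of isopropylamino on a sulfonyl sulfur; in this assay compound 2 gives 37 mg/kg, which is a 1.5-fold lower number from compound 1 to compound 2 (0.18 log units; within the scatter). Compound 3 `CC(C)NS(=O)(=O)Cc1noc2ccc(Cl)cc12` shares the core of compound 1 except for (chloro in place of hydrogen on an aromatic carbon), and in this assay compound 3 gives 100 mg/kg, so that a 1.8-fold higher number from compound 1 to compound 3 (0.25 log units; within the scatter). Compound 4 `CN(C)S(=O)(=O)Cc1noc2ccc(Cl)cc12` has not yet been measured. It differs from compound 3 by dimethylamino in place of isopropylamino on a sulfonyl sulfur, which is the same change that separates compound 1 from compound 2, the place being the same word for word in both pairs, while the two cores differ only as described above for compound 3 against compound 1. Among the compounds with values here, since the earlier step was small and within the scatter, a similar small step is expected from compound 3 to compound 4, namely a 1.5-fold lower number from compound 3 to compound 4 (0.17 log units; within the scatter), resting on the single precedent of compound 1 to compound 2 and on the value of compound 3. On that basis compound 4 is estimated to give 67 mg/kg in this assay, with a plausible range from 35 mg/kg to 130 mg/kg.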

Compound 4, dose for half-maximal effect: 57 mg/kg
Estimate against measurement, compound 4: 1.2-fold (0.07 log units) above; measured number inside the range.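

In this assay, dimethylamino in place of isopropylamino on a sulfonyl sulfur gives a 1.8-fold lower number from compound 3 to compound 4 (0.24 log units; within the scatter), and this agrees with the same change on the other core: the same change on two cores in this assay, a 1.5-fold lower number (0.18 log units; within the scatter) from compound 1 to compound 2 and a 1.8-fold lower number (0.24 log units; within the scatter) from compound 3 to compound 4, 1.2-fold (0.06 log units) apart, within the scatter of two such steps. Chloro in place of hydrogen on an aromatic carbon, read with dimethylamino on the sulfonyl sulfur, gives a 1.5-fold higher number from compound 2 to compound 4 (0.19 log units; within the scatter), and this also agrees with its earlier counterpart: the same change on two cores in this assay, a 1.8-fold higher number (0.25 log units; within the scatter) from compound 1 to compound 3 and a 1.5-fold higher number (0.19 log units; within the scatter) from compound 2 to compound 4, 1.2-fold (0.06 log units) apart, within the scatter of two such steps. Across these four compounds, both changes therefore carry from one core to the other without a discernible difference, but every step lies within the scatter, so this does not show that either change has a real effect of its own, and a single pair of cores does not show that the agreement extends further.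

The compounds shown leave open whether another group on the sulfonyl sulfur, such as an unsubstituted amino group or a longer alkylamino chain, would give a step beyond the scatter. They also leave open whether fluoro or methoxy in place of chloro would carry between the cores in the same way.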